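Methyl to Ethyl on the Ring Amine: Expected Cytotoxicity

The source may hold more compounds than are shown below. What is called first, only, known or untested is meant among the compounds shown, and "the series" means these compounds.

Compound 1 `CN1CCN(CCC(=O)O[C@@H]2C[C@@H]3CC[C@@]2(C)C3(C)C)CC1` and compound 2 `CCN1CCN(CCC(=O)O[C@@H]2C[C@@H]3CC[C@@]2(C)C3(C)C)CC1` are built on one shared core, and compound 2 carries the change (methyl in place of hydrogen on a saturated chain carbon bound to an amine nitrogen in a ring). In an ADME assay on HEK-293T cells (Homo sapiens) for cytotoxicity, read by MTT assay, with a stated time of 48 h (on this read-out lower numbers stand for higher toxicity in this test and higher numbers for lower toxicity in this test), compound 1 gives 282000 nM, and in this assay compound 2 gives 264000 nM. The step between them is a 1.1-fold lower number from compound 1 to compound 2 (0.03 log units; within the scatter), so the two numbers cannot be told apart here.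

Compound 3 `CN1CCN(CCCC(=O)N[C@@H]2C[C@H]3CC[C@]2(C)C3(C)C)CC1` rests on a different core; the difference between the two cores is not broken down here. In this assay compound 3 gives 475000 nM. Its number and those of compound 1 and compound 2 all sit within the usual scatter of one another, so no ordering among the three is claimed.

Compound 4 `CCN1CCN(CCCC(=O)N[C@@H]2C[C@H]3CC[C@]2(C)C3(C)C)CC1` differs from compound 3 by methyl in place of hydrogen on a saturated chain carbon bound to an amine nitrogen in a ring. The place of this change is described in exactly the same words as the change from compound 1 to compound 2, so it is taken as the same change, made a second time on the core of compound 3. Going by the values given here, the only guide to its effect is the single earlier instance, which stayed within the scatter, and the expectation for compound 4 rests on that step a 1.1-fold lower number from compound 1 to compound 2 (0.03 log units; within the scatter). The step from compound 3 to compound 4 is therefore expected to be a 1.1-fold lower number from compound 3 to compound 4 (0.03 log units; within the scatter). Compound 4 is estimated to give 440000 nM in this assay, with the expected range running from 250000 nM to 780000 nM.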

Compound 4, half-maximal cytotoxic concentration: 268000 nM
Estimate against measurement, compound 4: 1.6-fold (0.22 log units) above, and the stated range covers the measured number.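

In this assay, putting ethyl in place of methyl on the ring amine of the second core gives a 1.8-fold lower number from compound 3 to compound 4 (0.25 log units; within the scatter), so the numbers for this pair cannot be told apart, just as those of the first pair could not. Set side by side, the two instances of the change do not differ from each other: the same change on two cores in this assay, a 1.1-fold lower number (0.03 log units; within the scatter) from compound 1 to compound 2 and a 1.8-fold lower number (0.25 log units; within the scatter) from compound 3 to compound 4, 1.7-fold (0.22 log units) apart, within the scatter of two such steps. This shows that, on the two cores shown, going from 4-methylpiperazin-1-yl to 4-ethylpiperazin-1-yl stayed within the scatter both times and that the first step gave a fair guide to the second, but it does not show that the change is without effect on every core in the series, and two pairs within the scatter cannot reveal any small effect that might be hidden there.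

The compounds shown leave open whether a longer chain such as propyl, a branched group such as isopropyl, or a bare hydrogen on that ring amine would also stay within the scatter in this assay. They also leave open whether the step from methyl to ethyl would hold on a core carrying a carboxylic acid or an aromatic ring.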